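Replacing the amide side chain of compound 1

This account rests on a few compounds, and the source may have more. Where it says the series, first, only, none or still open, it means among the compounds named here.

Going by the values given here, in a functional assay on HepG2 cells (Homo sapiens), read by MTT assay, with a stated time of 48 h (on this read-out lower numbers stand for stronger inhibition and higher numbers for weaker inhibition), compound 1 (`CCn1c(C(=O)NCCN(C)C)ccc1C(CC)(CC)c1ccc(OCC(=O)C(C)(C)C)c(C)c1`) gives 2300 nM and stands highest of the two numbers so far, while compound 2 (`CCn1c(C(=O)NCCN(C)C)ccc1C(CC)(CC)c1ccc(OCC(O)C(C)(C)C)c(C)c1`) gives 870 nM as the lower one. Among the compounds with values here, the only measured step is a 2.6-fold lower number from compound 1 to compound 2 (0.42 log units; beyond the scatter) and is modest but beyond the scatter. It replaces (tert-butyl)carbonyl with 1-hydroxy-2,2-dimethylpropyl and leaves the amide untouched. Compound 3 (`CC[C@@H](C)[C@H](NC(=O)c1ccc(C(CC)(CC)c2ccc(OCC(=O)C(C)(C)C)c(C)c2)n1CC)C(=O)O`) keeps the (tert-butyl)carbonyl and instead carries 1-carboxy-2-methylbutyl in place of 2-(dimethylamino)ethyl on an amide-type nitrogen. Within the data shown here, no measurement yet covers a change at that nitrogen, so direction is a tentative call and the range stays wide. A modest step toward a higher number is expected (a 2.4-fold higher number from compound 1 to compound 3 (0.38 log units; beyond the scatter)). For compound 3 the estimated value is 5500 nM (expected range 1300 nM to 23000 nM).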

Compound 3, half-maximal inhibitory concentration: 247 nM
Compound 3: the middle estimate sits 22-fold (1.35 log units) above what was measured; measured number outside the range, below it.
By their numbers in this assay, from the lowest: compound 3; then compound 2; then compound 1.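

At the amide-type nitrogen, 1-carboxy-2-methylbutyl in place of 2-(dimethylamino)ethyl gives a 9.3-fold lower number from compound 1 to compound 3 (0.97 log units; beyond the scatter) in this assay, so the number at this position responds to the side chain, and a value this low does not require the dimethylamino group. The step is read on a single background, with the (tert-butyl)carbonyl kept, and for an entering group with two defined stereocentres. Nothing available accounts for the direction or size of this step.

Still open, going by these compounds, is which part of the new group carries the step: the carboxylic acid, tested against its methyl ester, or the branched chain, tested against a plain carboxymethyl group. Also open, on these data alone, are the other stereoisomers and whether the step holds alongside 1-hydroxy-2,2-dimethylpropyl.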